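A chlorophenyl swap at the cytotoxicity limit

A few compounds are considered here, and "the series" means these few. Any claim that something is new, unique, unknown or untested is made for them only; others in the source may bear on it.

In a functional assay on UACC-62 cells (Homo sapiens) for cytotoxicity, read by sulforhodamine B assay (on this read-out higher numbers stand for lower toxicity in this test and lower numbers for higher toxicity in this test), compound 3 `CC1=CC[C@@H]([C@@](C)(O)CCCC(C)(C)NC(=S)N/N=C\c2ccc(N(C)C)cc2)CC1` gives > 100000 nM, which is a limit and not a number. Compound 1 `CC1=CC[C@@H]([C@@](C)(O)CCCC(C)(C)NC(=S)NN)CC1` gives > 100000 nM, again a limit. Compound 3 therefore stands at the limit of > 100000 nM in this assay, at which 2 of the 3 values shown sit. Compound 2 `CC1=CC[C@@H]([C@@](C)(O)CCCC(C)(C)NC(=S)N/N=C\c2ccc(C)cc2)CC1` gives a true number of 52300 nM. Compound 4 `CC1=CC[C@@H]([C@@](C)(O)CCCC(C)(C)NC(=S)N/N=C\c2cccc(Cl)c2)CC1` brings this change: 3-chlorophenyl in place of 4-(dimethylamino)phenyl on a carbon with a double bond to nitrogen. For the measured compounds named here, two measured steps bear on it, an at least 1.9-fold lower number from compound 1 to compound 2 (0.28 log units; that floor lies within the scatter) and an at least 1.9-fold higher number from compound 2 to compound 3 (0.28 log units; that floor lies within the scatter), and both are small floors within the scatter. Going by the values given here, compound 2, at 52300 nM, is the only guide with a true number, so a modest move towards a lower number is expected, an at least 2.2-fold lower number from compound 3 to compound 4 (0.34 log units; beyond the scatter). The estimated value for compound 4 is 45000 nM, with an expected range of 15000 nM to 100000 nM.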

Compound 4, concentration lethal to 50% of the cells: 42700 nM
Compound 4: middle estimate off by 1.1-fold (0.02 log units), on the high side; the range from low to high includes it.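

In this assay, 3-chlorophenyl in place of 4-(dimethylamino)phenyl gives an at least 2.3-fold lower number from compound 3 to compound 4 (0.36 log units; beyond the scatter), and building the whole 3-chlorophenyl group onto the shared core gives an at least 2.3-fold lower number from compound 1 to compound 4 (0.36 log units; beyond the scatter). Swapping 4-methylphenyl for 3-chlorophenyl gives a 1.2-fold lower number from compound 2 to compound 4 (0.09 log units; within the scatter), so these two rings cannot be told apart in this test. The two larger steps are floors and not true sizes: the limit of > 100000 nM in this assay, at which 2 of the 4 values shown sit.

As far as these compounds go, what an amine or a carboxylic acid on this ring would do stays open. So does whether 4-chlorophenyl would match 3-chlorophenyl.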